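Chloro to methoxy on the aromatic ring

The source may hold more compounds than are shown below. What is called first, only, known or untested is meant among the compounds shown, and "the series" means these compounds.

Compound 1 `S=C1NCCN1Cc1ccccc1`: > 10000 nM
Compound 2 `Cc1ccc(CN2CCNC2=S)cc1`: 4800 nM
Compound 3 `S=C1NCCN1Cc1ccc(Cl)cc1`: 4300 nM

All three compounds were tested in a functional assay on B16 cells (Mus musculus) for inhibition, with a stated time of 72 h; on this read-out higher numbers stand for weaker inhibition and lower numbers for stronger inhibition. The entry for compound 1, > 10000 nM, is a limit of the assay and not a number. Compound 2 gives 4800 nM and compound 3 gives 4300 nM. Among the compounds with values here, these two values are the only true numbers in the set, and a 1.1-fold lower number from compound 2 to compound 3 (0.05 log units; within the scatter) leaves them within the scatter of each other, so compound 3 stands level with compound 2.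

Compound 4 `COc1ccc(CN2CCNC2=S)cc1` has not yet been measured. It carries methoxy in place of chloro on an aromatic carbon, para to a group of 7 heavy atoms: methoxy in place of chloro on an aromatic carbon.

Within the data shown here, three measured steps bear on this change. Replacing the aromatic hydrogen gave an at least 2.0-fold lower number from compound 1 to compound 2 (0.31 log units; beyond the scatter) with methyl and an at least 2.3-fold lower number from compound 1 to compound 3 (0.36 log units; beyond the scatter) with chloro, both beyond the scatter. Among the measured compounds shown here, the closest precedent is the exchange of one such group for another, a 1.1-fold lower number from compound 2 to compound 3 (0.05 log units; within the scatter), which stays within the scatter. As far as these compounds go, on that precedent, no step beyond the scatter is expected in this assay, although methoxy itself is untested here.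

The expected step is a 1.2-fold higher number from compound 3 to compound 4 (0.07 log units; within the scatter). For compound 4 the estimated value is 5000 nM, with an expected range from 2200 nM to 11000 nM.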

Compound 4, half-maximal inhibitory concentration: > 10000 nM
Compound 4 was reported as a limit (the forecaster's own chance of this, stated with the estimate: 15%); middle value at least 2.0-fold (0.30 log units) away from the limit.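

Within the data shown here, until this result, the only exchange of one group for another at this position, para to a group of 7 heavy atoms, had stayed within the scatter. Methoxy breaks with that precedent: in place of chloro it gives an at least 2.3-fold higher number from compound 3 to compound 4 (0.36 log units; beyond the scatter), and in place of methyl it gives an at least 2.0-fold higher number from compound 2 to compound 4 (0.31 log units; beyond the scatter). So in this assay the position does not accept every group alike, and methyl and chloro, which stand level with each other, part from methoxy even though it adds only one more heavy atom and a hydrogen-bond acceptor.

The value of compound 4 is a limit of the assay and not a number, and the step between compound 1 and compound 4 cannot be read because both compounds sit at that same limit: the limit of > 10000 nM in this assay, at which 2 of the 4 values shown sit.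

As far as these compounds go, what stays open is whether the oxygen of methoxy or the extra heavy atom goes with the weaker inhibition, which a hydroxyl or an ethyl at this position could separate. Whether an amine or a carboxylic acid here would stand with compound 2 and compound 3 or with compound 4 is also left open.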